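Methyl on the shared core of compound 1

A few compounds are considered here, and "the series" means these few. Any claim that something is new, unique, unknown or untested is made for them only; others in the source may bear on it.

Compound 1 `N=C(N)N/N=C/c1c(-c2cccs2)nc2sccn12` gives 25700 nM in a functional assay on cells (Cancer cell lines, Homo sapiens) for inhibition (a higher number here means a weaker inhibitor of growth, a lower number a stronger inhibitor of growth), the lowest of the two numbers shown, though compound 2 `N=C(N)N/N=C/c1c(-c2ccsc2)nc2sccn12`, which gives 28800 nM, stands within the scatter of it: a 1.1-fold higher number from compound 1 to compound 2 (0.05 log units; within the scatter). Compound 3 `Cc1cn2c(/C=N/NC(=N)N)c(-c3cccs3)nc2s1` differs from compound 1 by methyl in place of hydrogen on an aromatic carbon. Going by the values given here, no measured step touches this position; the only known step, thiophen-3-yl for thiophen-2-yl, lies within the scatter and says nothing about a methyl. For compound 3 in this assay no shift beyond the scatter is expected, a 1.0-fold lower number from compound 1 to compound 3 (0.01 log units; within the scatter). Compound 3 is therefore estimated at 25000 nM, between 9000 nM and 70000 nM.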

Compound 3, concentration for total growth inhibition: 11700 nM
For compound 3 the middle estimate is 2.1-fold (0.33 log units) above the measured one, within the range that was stated.
By their numbers in this assay, from the lowest: compound 3; then compounds 1 and 2 (each within the scatter of the next).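

In this assay, going by these compounds alone, methyl in place of hydrogen on an aromatic carbon next to the ring sulfur gives the first step beyond the scatter (a 2.2-fold lower number from compound 1 to compound 3 (0.34 log units; beyond the scatter)). The thiophen-3-yl change stayed within the scatter (a 1.1-fold higher number from compound 1 to compound 2 (0.05 log units; within the scatter)), so this carbon of the shared core is the only position shown to move the number, and only modestly. Nothing available explains this shift.

Open, from the compounds shown here alone, is whether an ethyl group, a longer chain, an amine or a carboxylic acid on this carbon would shift the number further. Also open, going by these compounds, is whether methyl gives a similar step alongside thiophen-3-yl.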